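Chloro for methyl on the compound 1 scaffold

A few compounds are considered here, and "the series" means these few. Any claim that something is new, unique, unknown or untested is made for them only; others in the source may bear on it.

Measured in a functional assay on HUVEC cells (Homo sapiens) for inhibition, using NADPH, with a stated time of 2 h; a lower number here means a stronger inhibitor, a higher number a weaker inhibitor:
- compound 1 `Cc1ccc2[nH]c(COc3cccc(OCC4CCOCC4)c3)c(C)c(=O)c2c1`: 38 nM
- compound 2 `Cc1c(COCCCCO)[nH]c2ccccc2c1=O`: 2600 nM

Working notes. Of the two numbers available in this assay, compound 1 holds the lower one at 38 nM. Compound 2 gives 2600 nM, a gap well beyond the scatter. The two differ in more than one place, so this gap does not isolate any single structural change.

The next compound is compound 3 `Cc1c(COc2cccc(OCC3CCOCC3)c2)[nH]c2ccc(Cl)cc2c1=O`, still to be measured in this assay. Its difference from compound 1 is chloro in place of methyl on an aromatic carbon. The change is chloro in place of methyl on an aromatic carbon, and the rest of the structure stays the same.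

Going by the values given here, no measured pair in this small set shows a change at this place, so the expectation is anchored only on compound 1 at 38 nM. The change is a single-atom swap, and no shift beyond the scatter is expected in this assay. The expected move is a 1.2-fold lower number from compound 1 to compound 3 (0.07 log units; within the scatter). For compound 3 the estimated value is 32 nM, with an expected range of 12 nM to 90 nM.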

Compound 3, half-maximal inhibitory concentration: 5 nM
Compound 3: the middle estimate sits 6.4-fold (0.81 log units) above what was measured; measured number below the stated range.
By their numbers in this assay, from the lowest: compound 3; then compound 1; then compound 2.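

In this assay, the aromatic carbon meta to a fused ring and para to a fused ring proves responsive to substitution: chloro in place of methyl gives a 7.6-fold lower number from compound 1 to compound 3 (0.88 log units; beyond the scatter), a step beyond the scatter. Until this pair, no measured comparison in the series addressed this position, and the values for compound 1 and compound 2 could not isolate any single structural change. The step arises from an exchange of one heavy atom for one heavy atom, with no ring, hydrogen-bond donor, hydrogen-bond acceptor or net charge entering or leaving, so a substantial change in the number here does not depend on any difference in those counts. Nothing measured here explains why this swap moves the number.

Whether the trend extends beyond chloro remains open, since the compounds shown give no reading for fluoro, bromo, trifluoromethyl, methoxy or an amine at this carbon, nor for hydrogen alone. Also open, going by these compounds, is whether chloro gives a step of similar size when the aryloxymethyl side chain of compound 3 is replaced, for example by a longer chain ending in a carboxylic acid.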